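Swapping a Nitrile for an Amine on a Second Core

The source may hold more compounds than are shown below. What is called first, only, known or untested is meant among the compounds shown, and "the series" means these compounds.

Of the compounds shown here, three have been measured in an assay on Cerebral cortex for binding affinity to adenosine receptor A1 (Cavia porcellus), read by radioligand binding; on this read-out lower numbers stand for stronger inhibition and higher numbers for weaker inhibition. Compound 1 `CCCn1c(=O)n(CCC#N)c(=O)c2[nH]cnc21` gives 15900 nM in this assay, and compound 2 `CCCn1c(=O)n(CCN(C)C)c(=O)c2[nH]cnc21` gives 4300 nM. The two differ in one place, (dimethylamino in place of cyano on a saturated chain carbon, two bonds along the chain from an aromatic nitrogen), and that single change made a step of a 3.7-fold lower number from compound 1 to compound 2 (0.57 log units; beyond the scatter). Compound 3 `CCCn1c(=O)n(C)c(=O)c2c1ncn2CCC#N` is built on a different core; in this assay compound 3 gives 88600 nM, the highest of the three numbers, with compound 1 and compound 2 both well away from it. The difference between the core of compound 1 and the core of compound 3 is not broken down here.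

Compound 4 `CCCn1c(=O)n(C)c(=O)c2c1ncn2CCN(C)C` has not been measured. It differs from compound 3 by dimethylamino in place of cyano on a saturated chain carbon, two bonds along the chain from an aromatic nitrogen, the same kind of change that separates compound 1 from compound 2, and the place given for it reads the same word for word. The change occurs twice among the four compounds, once measured and once not. Because a 3.7-fold lower number from compound 1 to compound 2 (0.57 log units; beyond the scatter) lay beyond the scatter, a step of roughly that size is expected again, although the core of compound 3 is not that of compound 1, so the expectation rests on a single precedent. The step from compound 3 to compound 4 is expected to be a 3.5-fold lower number from compound 3 to compound 4 (0.55 log units; beyond the scatter). In this assay compound 4 is estimated at 25000 nM, with a range from 8000 nM to 80000 nM.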

Compound 4, inhibition constant: > 200000 nM
Compound 4: a limit, no number; the forecaster's own chance of this, stated with the estimate: 10%; middle value at least 8.0-fold (0.90 log units) away from the limit.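

In this assay compound 4 gives no number, only a limit of the assay: the limit of > 200000 nM in this assay, at which 1 of the 4 values shown sits. Even with that limit the direction can be read, and dimethylamino in place of cyano does not carry over from one core to the other: the second core gives an at least 2.2-fold higher number from compound 3 to compound 4 (0.35 log units; beyond the scatter), against a 3.7-fold lower number from compound 1 to compound 2 (0.57 log units; beyond the scatter) on the first, so the two steps run in opposite directions: the same change on two cores in this assay, a 3.7-fold lower number (0.57 log units; beyond the scatter) from compound 1 to compound 2 and an at least 2.2-fold higher number (0.35 log units; beyond the scatter) from compound 3 to compound 4, at least 8.3-fold (0.92 log units) apart, beyond the scatter of two such steps. For the compounds shown here, this shows that, for these two cores, the step measured on one did not predict the step on the other, but it does not give the true size of the step on the second core, which remains open-ended, and it rests on only one pair per core and gives no reason for the difference.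

The compounds shown leave open whether a primary amine or a carboxylic acid in place of the dimethylamino group, or a longer chain carrying it, would follow the pattern of the first core or the second. They also leave open which part of the difference between the core of compound 1 and the core of compound 3 goes with the opposite outcome, since that difference is not broken down here.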